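Aryl urea series on the shared core: expected potency of compound 4

The source may report more compounds than this note shows. Statements on the series, on what has been measured and on what is new or still open speak of the compounds shown alone.

Measured so far:
- compound 1 `COc1cc(NC(C)CCCNC(=O)Nc2ccc(Br)cc2)c2ncccc2c1`: 2600 nM
- compound 2 `COc1cc(NC(C)CCCNC(=O)NNC(=O)Nc2ccc(F)cc2)c2ncccc2c1`: 310 nM
- compound 3 `COc1cc(NC(C)CCCNC(=O)NNC(=O)Nc2ccc(Br)cc2)c2ncccc2c1`: 100 nM

In a functional assay on MCF7 cells (Homo sapiens) for inhibition, read by MTT assay, with a stated time of 72 h (a higher number here means a weaker inhibitor, a lower number a stronger inhibitor), compound 2 gives 310 nM and stands second highest of the three numbers, with compound 3 nearest and compound 1 furthest away: a 3.1-fold lower number from compound 2 to compound 3 (0.49 log units; beyond the scatter); an 8.4-fold lower number from compound 1 to compound 2 (0.92 log units; beyond the scatter).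

Compound 4 `COc1cc(NC(C)CCCNC(=O)Nc2cccc(C(F)(F)F)c2)c2ncccc2c1` is not yet measured. Its difference from compound 2: 3-(trifluoromethyl)phenyl in place of ((4-fluorophenyl)carbamoyl)amino on an amide-type nitrogen.

Among the compounds with values here, two measured steps bear on this change. Both run in the opposite direction, adding the carbamoylamino unit to an aryl urea: an 8.4-fold lower number from compound 1 to compound 2 (0.92 log units; beyond the scatter) and a 26-fold lower number from compound 1 to compound 3 (1.41 log units; beyond the scatter). Removing that unit is therefore expected to raise the number. Within the data shown here, compound 4 shares with compound 1 the arrangement in which the aryl ring is attached to the amide-type nitrogen, so compound 1 is the closest guide; no measured step covers the change from 4-bromophenyl to 3-(trifluoromethyl)phenyl, and that part is open.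

Compound 4 is expected to be a weaker inhibitor than compound 2, with the step of an 8.1-fold higher number from compound 2 to compound 4 (0.91 log units; beyond the scatter) estimated to be beyond the scatter. The estimate for compound 4 in this assay is 2500 nM, within a range of 800 nM to 8000 nM.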

Compound 4, half-maximal inhibitory concentration: 3300 nM
Beside the measured number, compound 4's estimate is 1.3-fold (0.12 log units) below it; the range from low to high includes it.
By their numbers in this assay, from the lowest: compound 3; then compound 2; then compounds 1 and 4 (each within the scatter of the next).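

In this assay, 3-(trifluoromethyl)phenyl on the amide-type nitrogen in place of either carbamoylamino-bearing group raises the number sharply, whether the group that leaves is ((4-fluorophenyl)carbamoyl)amino (an 11-fold higher number from compound 2 to compound 4 (1.03 log units; beyond the scatter)) or ((4-bromophenyl)carbamoyl)amino (a 33-fold higher number from compound 3 to compound 4 (1.52 log units; beyond the scatter)). The aryl ring itself makes no resolvable difference at this position when the carbamoylamino unit is absent, as 3-(trifluoromethyl)phenyl in place of 4-bromophenyl stays within the scatter (a 1.3-fold higher number from compound 1 to compound 4 (0.10 log units; within the scatter)), so the link between this unit and the lower numbers now rests on two aryl groups without it, and none of the four compounds goes against it. Nothing available gives a reason for these steps.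

Going by these compounds, it remains open whether 3-(trifluoromethyl)phenyl carried on the carbamoylamino unit would give a number as low as those of compound 2 and compound 3, as the aryl groups in the two forms do not yet overlap. Also open, on these data alone, is whether an amine or a carboxylic acid on the aryl ring, or a longer chain in place of the carbamoylamino unit, would keep those lower numbers.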